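This account rests on a few compounds, and the source may have more. Where it says the series, first, only, none or still open, it means among the compounds named here.

Measured compounds:

Compound 1, `CNc1ncnc(Nc2ccc(Cl)c(OCC=C(C)C)c2)n1`, gives 3100 nM in an ADME assay on MT2 cells (Homo sapiens) for cytotoxicity; a higher number here means that more compound is tolerated, a lower number that less compound is tolerated.
Compound 2, `CC(C)=CCOc1cc(Nc2nccc(N)n2)ccc1Cl`, gives 500 nM in this assay.
Compound 3, `COc1cc(N)nc(Nc2ccc(Cl)c(OCC=C(C)C)c2)n1`, gives 19000 nM in this assay.

Compound 2 has the lowest number of the three, meaning that of these compounds the cells tolerate it least. Compound 1 gives a higher number than compound 2, and compound 3 lies further away still, with a 38-fold higher number from compound 2 to compound 3 (1.58 log units; beyond the scatter), a large shift for a single added methoxy.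

Compound 4, `CC(C)=CCOc1cc(Nc2ncccn2)ccc1Cl`, is made from compound 2 by a single change: hydrogen in place of amino on an aromatic carbon. Among the compounds with values here, none of the measured steps concerns an amino group; the only measured single-point step, from compound 2 to compound 3, adds a methoxy elsewhere on the shared core and gives no guidance on removing an amino. Within the data shown here, the expectation for compound 4 therefore rests on no close precedent, and the direction of any step is open. Compound 4 is expected to give about 1000 nM in this assay, with a plausible range from 300 nM to 4000 nM. The step from compound 2 to compound 4 is estimated at a 2.0-fold higher number from compound 2 to compound 4 (0.30 log units; within the scatter), which may prove to lie within the scatter once measured.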

Compound 4, half-maximal cytotoxic concentration: 2500 nM
For compound 4 the middle estimate is 2.5-fold (0.40 log units) below the measured one; the range from low to high includes it.
By their numbers in this assay, from the lowest: compound 2; then compounds 4 and 1 (each within the scatter of the next); then compound 3.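

Replacing the amino group with hydrogen, on the aromatic carbon next to the ring nitrogen, gives a 5.0-fold higher number from compound 2 to compound 4 (0.70 log units; beyond the scatter) in this assay, so at this position the cells tolerate more compound once the amino group is gone. Together with a 38-fold higher number from compound 2 to compound 3 (1.58 log units; beyond the scatter), this shows that two different single changes to compound 2 both raise the number, though the methoxy step is the larger of the two and the hydrogen step is only modest. Nothing measured here says why removing the amino group has this effect.

The compounds shown leave open what other groups on this same carbon would do: a methyl group, a chlorine atom or a dimethylamino group might give a number close to that of compound 2, close to that of compound 4, or away from both. Going by these compounds, it also remains open whether replacing the amino group with hydrogen would raise the number by a similar amount in compound 3, which keeps that amino group and also carries the methoxy.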